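This account rests on a few compounds, and the source may have more. Where it says the series, first, only, none or still open, it means among the compounds named here.

Measured so far in the series:
compound 1, `O=C(O)c1cc(-c2cccc(COc3ccc4c(=O)n(C5CCC5)sc4c3)c2)ccc1Cl`: 67%
compound 2, `O=C1c2ccc(OCc3cccc(-c4ccc(C(F)(F)F)cc4F)c3)cc2CN1C1CCCC1`: "not determined" (no result reported)
compound 3, `O=C(O)c1cc(-c2cccc(COc3ccc4c(=O)n(C5CCCC5)sc4c3)c2)cc([N+](=O)[O-])c1`: 84%

In an ADME assay on microsomes from liver (Rattus norvegicus) for metabolic stability, read by LC-MS, with a stated time of 1 h, at 37 degrees C, tested at 4 uM (a higher number here means that more of the compound is left, a lower number that less of the compound is left), compound 1 gives 67% and compound 3 gives 84%. Both are built on a core other than that of compound 2 and both carry a carboxylic acid, so they serve only as a loose frame for the series, not as anchors for the pair treated here.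

Compound 2 stands on no number in this assay: its entry reads "not determined" (no result reported), and it therefore has no place among the values shown. Compound 4, `O=C1c2ccc(OCc3cccc(-c4ccccc4)c3)cc2CN1C1CCCC1`, is its unmeasured partner. The change between the two is phenyl in place of 2-fluoro-4-(trifluoromethyl)phenyl on an aromatic carbon.

No step between measured compounds exists for this pair, and with compound 2 lacking a value, neither the size nor the direction of the step in this assay can be read from the data; any expectation rests on the spread shown by compounds 1 and 3 and on the change touching a single terminal ring. Compound 4 is expected to give roughly 45%, estimated to fall between 15% and 80%.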

Compound 4, percent of the compound remaining: 38%
The estimate for compound 4 lay 7 percentage points above the measured number; measured number inside the range.
By their numbers in this assay, from the lowest: compound 4; then compound 1; then compound 3.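

In this assay compound 4 gives 38%, but no new step can be read, as compound 2 has no single number to compare with it. The compounds shown leave open how exchanging 2-fluoro-4-(trifluoromethyl)phenyl for phenyl shifts the compound remaining. No supporting evidence bears on this result.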